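Fluoro on the benzyl of a cytotoxicity-silent imine

The source may report more compounds than this note shows. Statements on the series, on what has been measured and on what is new or still open speak of the compounds shown alone.

Measured so far:
compound 1, `Cc1ccc(S(=O)(=O)n2cc(/C=N\c3ccc(N4CCOCC4=O)cc3)c3ccccc32)cc1`, in an ADME assay on BV-2 cells (Mus musculus) for cytotoxicity, read by MTT assay, with a stated time of 48 h; on this read-out higher numbers stand for weaker inhibition and lower numbers for stronger inhibition: > 100000 nM (a limit of the assay)
compound 2, `O=C1COCCN1c1ccc(/N=C\c2cn(Cc3ccccc3)c3ccccc23)cc1`, in this assay: > 100000 nM (a limit of the assay)

Compound 2 stands at the limit of this assay, and nothing more than that limit is known for it. For the measured compounds named here, the one structural neighbour, compound 1, also reaches only a limit, so the step from compound 1 to compound 2 is a step that the two limits leave unreadable from compound 1 to compound 2. Going by the values given here, both values shown rest at the limit of > 100000 nM in this assay, at which 2 of the 2 values shown sit, which is the only evidence the measured steps give.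

Compound 3, `O=C1COCCN1c1ccc(/N=C\c2cn(Cc3ccc(F)cc3)c3ccccc23)cc1`, differs from compound 2 by fluoro in place of hydrogen on an aromatic carbon. Among the compounds with values here, no measured step bears on this change: the only step recorded is unreadable, and neither measured compound carries a fluoro group. With the two values shown both at the limit, the expected step from compound 2 to compound 3 in this assay is a step that the limit leaves unreadable from compound 2 to compound 3, none beyond the scatter. Compound 3 is therefore estimated at 150000 nM, with a range from 50000 nM to 500000 nM, and the most likely outcome is that the assay again reports only a limit for it.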

Compound 3, half-maximal inhibitory concentration: > 100000 nM
Compound 3: a limit, no number; the forecaster's own chance of this, stated with the estimate: 85%; the middle value does not contradict the limit.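

In this assay compound 3 gives > 100000 nM, which is a limit of the assay and not a number. No new step can be read from it, neither between compound 2 and compound 3 nor between compound 1 and compound 3. The compounds shown leave open whether any change to them would give a readable value, since all rest at one limit: the limit of > 100000 nM in this assay, at which 3 of the 3 values shown sit.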